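The source may report more compounds than this note shows. Statements on the series, on what has been measured and on what is new or still open speak of the compounds shown alone.

Measured so far:

Compound 1, `O=C(N1CC=C[C@@H](O)[C@H]1COCc1ccccc1)n1cc(-c2ccc(-c3ccccc3)cc2)nn1`, in an assay on HEK293 cells for inhibition of diacylglycerol lipase-alpha (Homo sapiens), read by colorimetric assay, with stated times of 30 min, 60 s and 20 min (a lower number here means a stronger inhibitor, a higher number a weaker inhibitor), gives > 10000 nM; this is a limit of the assay, not a number.
Compound 2, `O=C(N1CCC=C[C@@H]1COCc1ccccc1)n1cc(-c2ccccc2)nn1`, in this assay gives 158 nM.
Compound 3, `O=C(N1CCC=C[C@@H]1COCc1ccccc1)n1cc(-c2ccc([N+](=O)[O-])cc2)nn1`, in this assay gives 15.9 nM.

Compound 3 holds the lowest of the two numbers in this assay. For the measured compounds named here, its nearest neighbour is compound 2, and the step of a 9.9-fold lower number from compound 2 to compound 3 (1.00 log units; beyond the scatter) is the only measured step between compounds that differ in one place. Going by the values given here, compound 1 sits at the limit of > 10000 nM in this assay, at which 1 of the 3 values shown sits, and its core differs from the others in more than one place, so it offers no single step.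

Compound 4, `O=C(N1CCC=C[C@@H]1COCc1ccccc1)n1cc(-c2ccc(Oc3ccccc3)cc2)nn1`, differs from compound 3 by phenoxy in place of nitro on an aromatic carbon. Among the compounds with values here, the step of a 9.9-fold lower number from compound 2 to compound 3 (1.00 log units; beyond the scatter) shows how much the nitro group contributed on this core; compound 4 no longer carries it, and no measured compound carries a phenoxy group in that place, so the phenoxy group itself is an unknown. The nitro gain is expected to be given back in this assay, so the step of a 9.4-fold higher number from compound 3 to compound 4 (0.97 log units; beyond the scatter) is expected to raise the number. Compound 4 is therefore estimated at 150 nM, within a range from 30 nM to 1500 nM.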

Compound 4, half-maximal inhibitory concentration: 25.1 nM
Compound 4: middle estimate off by 6.0-fold (0.78 log units), on the high side, and the stated range ends above it.
By their numbers in this assay, from the lowest: compounds 3 and 4 (each within the scatter of the next); then compound 2. At a limit, above all of these: compound 1.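

In this assay, for the compounds shown here, phenoxy in place of hydrogen on the aromatic carbon gives a 6.3-fold lower number from compound 2 to compound 4 (0.80 log units; beyond the scatter) and so, on this core, the nitro group is not the only group that beats hydrogen at this place. Replacing nitro with phenoxy gives a 1.6-fold higher number from compound 3 to compound 4 (0.20 log units; within the scatter) and leaves the two compounds indistinguishable in this assay, although nitro has 3 heavy atoms and no ring while phenoxy has 7 heavy atoms and a six-membered aromatic ring of carbon only. This place, para to a large group, therefore takes two groups with very different atom counts, and both give numbers clearly lower than the hydrogen of compound 2.

Two groups cannot show whether almost any group at this carbon would give the same gain, and an amine, a carboxylic acid, a methyl group or a longer chain ending in a phenyl ring at the same place would test that. Nothing measured here gives a reason why nitro and phenoxy land so close together.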